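The compounds below may be only part of what the source reports. "The series", "measured", "known", "first", "only" and "open" are said of these compounds alone.

Compound 1 `CCCCSc1nnc(COc2cc(C)c3c(C)cc(=O)oc3c2)o1`: in a functional assay on MDA-MB-231 cells (Homo sapiens) for antiproliferative activity, read by MTT assay, with a stated time of 24 h (a higher number here means a weaker inhibitor, a lower number a stronger inhibitor), compound 1 gives > 100000 nM, which is a limit of the assay and not a number.
Compound 2 `CCCCCSc1nnc(COc2cc(C)c3c(C)cc(=O)oc3c2)o1`: in this assay compound 2 gives > 100000 nM, again a limit.
Compound 3 `Cc1cc(OCc2nnc(SCc3ccccc3)o2)cc2oc(=O)cc(C)c12`: in this assay compound 3 gives > 100000 nM, also a limit.

Compound 3 therefore stands at the limit of this assay, where all three measured values sit (the limit of > 100000 nM in this assay, at which 3 of the 3 values shown sit). Compound 4 `CCS(=O)(=O)c1nnc(COc2cc(C)c3c(C)cc(=O)oc3c2)o1` differs from compound 3 by ethylsulfonyl in place of benzylsulfanyl on an aromatic carbon of the shared core. The measured steps bear only loosely on this change: a step that the two limits leave unreadable from compound 1 to compound 2, a step that the two limits leave unreadable from compound 1 to compound 3 and a step that the two limits leave unreadable from compound 2 to compound 3 each alter the group on the sulfur, yet none is readable in size, as both ends of every step rest on the limit. For the measured compounds named here, no measured step thus anchors a direction for compound 4, and the change itself swaps a sulfanyl for a sulfonyl, a kind of move no measured pair shows. Compound 4 is expected to stay at the limit, with an estimated step that the limit leaves unreadable from compound 3 to compound 4. Compound 4 is estimated at 150000 nM, between 50000 nM and 500000 nM.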

Compound 4, half-maximal inhibitory concentration: > 100000 nM
Compound 4 ended at the assay's limit (the forecaster's own chance of this, stated with the estimate: 80%); the middle value is on the limit's open side.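

No step from compound 1, compound 2 or compound 3 to compound 4 can be read, because all four compounds rest on the same limit: the limit of > 100000 nM in this assay, at which 4 of the 4 values shown sit.

The compounds shown leave open whether any group on the sulfur would give a measurable value in this assay.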